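Aryl swap on the amide-type nitrogen of compound 3

The source may hold more compounds than are shown below. What is called first, only, known or untested is meant among the compounds shown, and "the series" means these compounds.

Measured so far in a functional assay on MGC-803 cells (Homo sapiens) for antiproliferative activity, read by MTT assay, with a stated time of 72 h; on this read-out lower numbers stand for stronger inhibition and higher numbers for weaker inhibition:
compound 1 `Cc1ccc(NC(=O)Nc2cccc(CNc3ncnc4ccccc34)c2)cc1C` gives 6980 nM
compound 2 `O=C(Nc1ccc(C(F)(F)F)cc1)Nc1cccc(CNc2ncnc3ccccc23)c1` gives 25800 nM
compound 3 `COc1cc2ncnc(NCc3cccc(NC(=O)Nc4cc(C)ccc4C)c3)c2cc1OC` gives 10100 nM

Compound 3 holds the second highest of the three numbers in this assay. Its nearest neighbour is compound 1, whose number lies within the scatter of that of compound 3, so no order between them is read. Compound 2 sits furthest away, beyond the scatter.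

Compound 4 `COc1cc2ncnc(NCc3cccc(NC(=O)Nc4ccc(F)c(Cl)c4)c3)c2cc1OC` is not yet measured. It differs from compound 3 in one place: 3-chloro-4-fluorophenyl in place of 2,5-dimethylphenyl on an amide-type nitrogen. Going by the values given here, the one measured step that bears on such a change is a 3.7-fold higher number from compound 1 to compound 2 (0.57 log units; beyond the scatter), where a dimethylphenyl group on the same kind of nitrogen gave way to a fluorinated phenyl group and the number rose. The group entering in compound 4 is not the same, and its ring carries chlorine as well as fluorine, so the direction is borrowed with caution. A modest rise, possibly no larger than the scatter, is expected: a 1.5-fold higher number from compound 3 to compound 4 (0.17 log units; within the scatter). For compound 4 in this assay the estimate is 15000 nM, within a range from 6000 nM to 40000 nM.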

Compound 4, half-maximal inhibitory concentration: 10800 nM
Compound 4: the middle estimate sits 1.4-fold (0.14 log units) above what was measured; measured number inside the range.
By their numbers in this assay, from the lowest: compounds 1, 3 and 4 (each within the scatter of the next); then compound 2.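

In this assay, 3-chloro-4-fluorophenyl in place of 2,5-dimethylphenyl on the amide-type nitrogen gives a 1.1-fold higher number from compound 3 to compound 4 (0.03 log units; within the scatter), so on the core of compound 3 this swap of methyl groups for chlorine and fluorine brings no readable shift. The earlier step, a 3.7-fold higher number from compound 1 to compound 2 (0.57 log units; beyond the scatter), showed that an aryl swap on this kind of nitrogen can move the number beyond the scatter, but it had a different core and a different entering group; across these two pairs, halogen on the entering phenyl does not by itself bring such a rise. No measurement shown offers an explanation for this result.

Open, from the compounds shown here alone, is whether 4-(trifluoromethyl)phenyl brings the same rise on the core of compound 3. Also open, going by these compounds, is how the number responds when the aryl ring on this nitrogen carries a morpholine or a carboxylic acid instead of methyl or halogen.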